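Iodo in Place of Ethynyl on a Nucleoside

The compounds below may be only part of what the source reports. "The series", "measured", "known", "first", "only" and "open" are said of these compounds alone.

Within the data shown here, in a functional assay on CEM-DNR-bulk cells (Homo sapiens), read by MTT assay, with a stated time of 72 h (on this read-out lower numbers stand for stronger inhibition and higher numbers for weaker inhibition), compound 3 `C#Cc1cn([C@@H]2O[C@H](CO)[C@@H](O)[C@H]2O)c2ncnc(C)c12` gives 160 nM, the only true number among the measured compounds. Compound 1 `Cc1ncnc2c1c(-c1ccoc1)cn2[C@@H]1O[C@H](CO)[C@@H](O)[C@H]1O` gives > 20000 nM, which is a limit of the assay and not a number. Compound 2 `Cc1ncnc2c1c(-c1cccs1)cn2[C@@H]1O[C@H](CO)[C@@H](O)[C@H]1O` gives > 20000 nM, which is also a limit.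

Compound 4 `Cc1ncnc2c1c(I)cn2[C@@H]1O[C@H](CO)[C@@H](O)[C@H]1O` keeps the shared core of compound 3 and differs in one group: iodo in place of ethynyl on an aromatic carbon. Two measured steps change the same carbon, and both are large and beyond the scatter: an at least 120-fold lower number from compound 1 to compound 3 (2.09 log units; beyond the scatter) and an at least 120-fold lower number from compound 2 to compound 3 (2.09 log units; beyond the scatter). In each, a ring leaves and ethynyl enters. Iodo, like the ethynyl of compound 3 at 160 nM, brings no ring, so a return all the way to the readings of compound 1 and compound 2 is not the expected outcome. Among the measured compounds shown here, no measured step involves iodo, however, so some weakening is expected as a cautious assumption, and the uncertainty is wide. The expected change is a 5.0-fold higher number from compound 3 to compound 4 (0.70 log units; beyond the scatter), towards a higher number in this assay. For compound 4, the estimated value is 800 nM, with an expected range from 120 nM to 8000 nM.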

Compound 4, half-maximal inhibitory concentration: 12600 nM
For compound 4 the middle estimate is 16-fold (1.20 log units) below the measured one; measured number above the stated range.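

Until now, every step at this aromatic carbon swapped a ring for ethynyl, so the low number of compound 3 could have reflected simply the loss of a ring. Iodo brings no ring either, yet in this assay the change gives a 79-fold higher number from compound 3 to compound 4 (1.90 log units; beyond the scatter), so having no ring here is not enough to reach the number of compound 3. The comparisons with the ring-bearing compounds give only floors, an at least 1.5-fold lower number from compound 2 to compound 4 (0.20 log units; that floor lies within the scatter) and an at least 1.5-fold lower number from compound 1 to compound 4 (0.20 log units; that floor lies within the scatter), and their exact sizes cannot be read, since those two readings are limits: the limit of > 20000 nM in this assay, at which 2 of the 4 values shown sit.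

Going by these compounds, whether an amine, a nitrile or a longer chain ending in a triple bond on this carbon would stay near compound 3 or move towards compound 4 remains open. On these data alone, whether the same gap between ethynyl and iodo appears in other cells is also open.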